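Thiophene Attachment Point Across Two Hydroxyphenyl Cores

This account rests on a few compounds, and the source may have more. Where it says the series, first, only, none or still open, it means among the compounds named here.

In a functional assay on MDA-MB-231 cells (Homo sapiens) for cytotoxicity, read by ELISA, with a stated time of 2 days (on this read-out higher numbers stand for weaker inhibition and lower numbers for stronger inhibition), compound 1 `Oc1ccc(-c2cc(-c3ccccc3)cc(-c3cccs3)n2)cc1` gives 2400 nM. Compound 2 `Oc1ccc(-c2cc(-c3ccccc3)cc(-c3ccsc3)n2)cc1`, which carries thiophen-3-yl in place of thiophen-2-yl on an aromatic carbon, gives 5700 nM; the step is a 2.4-fold higher number from compound 1 to compound 2 (0.38 log units; beyond the scatter). Compound 3 `Oc1cccc(-c2cc(-c3ccccc3)nc(-c3cccs3)c2)c1` gives 17700 nM, the highest of the three numbers; how its core differs from the core of compound 1 is not broken down here. Compound 4 `Oc1cccc(-c2cc(-c3ccccc3)nc(-c3ccsc3)c2)c1` carries the same kind of change relative to compound 3, (thiophen-3-yl in place of thiophen-2-yl on an aromatic carbon), with the place meta to a 3-hydroxyphenyl group rather than a 4-hydroxyphenyl group. Because compound 3 already gives 17700 nM and the earlier step was a 2.4-fold higher number from compound 1 to compound 2 (0.38 log units; beyond the scatter), compound 4 is expected to move by about a 2.1-fold higher number from compound 3 to compound 4 (0.33 log units; beyond the scatter), a step of similar size in the same direction. The estimate for compound 4 is 38000 nM, between 15000 nM and 95000 nM.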

Compound 4, half-maximal inhibitory concentration: 19000 nM
Compound 4: the middle estimate sits 2.0-fold (0.30 log units) above what was measured; measured number inside the range.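

On the second core, thiophen-3-yl in place of thiophen-2-yl gives a 1.1-fold higher number from compound 3 to compound 4 (0.03 log units; within the scatter), so this pair shows no separation in this assay. Set beside the step on the first core, the two steps cannot be told apart: the same change on two cores in this assay, a 2.4-fold higher number (0.38 log units; beyond the scatter) from compound 1 to compound 2 and a 1.1-fold higher number (0.03 log units; within the scatter) from compound 3 to compound 4, 2.2-fold (0.34 log units) apart, within the scatter of two such steps. This fits a change that carries from one core to the other without a detectable difference, but two pairs do not show that the step is the same on both cores, since it lies beyond the scatter on one and within it on the other.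

As far as these compounds go, it remains open how a furan or a pyridine would compare with either thiophene on these cores. From the compounds shown here alone, the effect of an amine or a methoxy group in place of the hydroxy group also stays unknown.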